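Trifluoromethyl replaces hydroxymethyl on a pyrazole acid

A few compounds are considered here, and "the series" means these few. Any claim that something is new, unique, unknown or untested is made for them only; others in the source may bear on it.

The series rests on two measured compounds. Compound 1 `O=C(O)c1nn(Cc2cc(Br)ccc2OCc2ccccc2)cc1Br` gives 457 nM in an assay on CHO-K1 cells for displacement of a labelled ligand from prostaglandin E2 receptor EP1 subtype (Homo sapiens); on this read-out lower numbers stand for stronger inhibition and higher numbers for weaker inhibition. For the measured compounds named here, compound 2 `O=C(O)c1nn(Cc2cc(Br)ccc2OCc2ccccc2)cc1CO` gives 676 nM in this assay; its number lies within the usual scatter of that of compound 1, which is the only other compound measured, so the two cannot be ranked against each other. Going by the values given here, the single measured step, a 1.5-fold higher number from compound 1 to compound 2 (0.17 log units; within the scatter), is the only one that bears on the present change and it did not move the number beyond the scatter.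

Compound 3 `O=C(O)c1nn(Cc2cc(Br)ccc2OCc2ccccc2)cc1C(F)(F)F` carries trifluoromethyl in place of hydroxymethyl on an aromatic carbon. Among the compounds with values here, no measured step tests a trifluoromethyl group at this place. Given that the one relevant step stayed within the scatter, compound 3 is expected to show a 1.3-fold lower number from compound 2 to compound 3 (0.11 log units; within the scatter) in this assay, with no movement beyond the scatter. Compound 3 is therefore estimated at 520 nM, within a range from 200 nM to 1500 nM.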

Compound 3, half-maximal inhibitory concentration: 2570 nM
Compound 3: middle estimate off by 4.9-fold (0.69 log units), on the low side; measured number above the stated range.
By their numbers in this assay, from the lowest: compounds 1 and 2 (each within the scatter of the next); then compound 3.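

This position, on an aromatic carbon next to the ring atom that bears a carboxy group, does not treat all groups alike in this assay: bromo and hydroxymethyl could not be told apart, but the change to trifluoromethyl gives a 3.8-fold higher number from compound 2 to compound 3 (0.58 log units; beyond the scatter) and a 5.6-fold higher number from compound 1 to compound 3 (0.75 log units; beyond the scatter). For the compounds shown here, the earlier step within the scatter therefore did not mean that the number is indifferent to what this carbon carries, and trifluoromethyl is the first group here to move it beyond the scatter, towards weaker inhibition. Nothing available explains what in this change lies behind the higher number.

On these data alone, whether an amine, a nitrile or a methyl at this place would side with bromo and hydroxymethyl or with trifluoromethyl stays open. Also open, as far as these compounds go, is whether a step of this size would recur with an amide in place of the carboxy group.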